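Swapping an Indole for an Aminopyridine: Solubility Outlook

This account rests on a few compounds, and the source may have more. Where it says the series, first, only, none or still open, it means among the compounds named here.

Compound 1 `O=c1ncn(Cc2c(F)cc(F)cc2F)c2ccc(Oc3cccc(-c4ccc5[nH]ccc5c4)c3C(F)(F)F)cc12` gives < 0.1 ug/mL in a physicochemical assay for solubility, using the shake flask method, with a stated time of 24 h, at pH 2 (on this read-out lower numbers stand for lower solubility and higher numbers for higher solubility), which is a limit of the assay rather than a number.
Compound 2 `O=c1ncn(Cc2c(F)cc(F)cc2F)c2ccc(Oc3cccc(-c4ccc5cc[nH]c5c4)c3C(F)(F)F)cc12` gives < 0.1 ug/mL in this assay, again only a limit.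
Compound 3 `Nc1ccc(-c2cccc(Oc3ccc4c(c3)c(=O)ncn4Cc3c(F)cc(F)cc3F)c2C(F)(F)F)cn1` gives 0.3 ug/mL in this assay.

Compound 1 thus stands at the limit of < 0.1 ug/mL in this assay, at which 2 of the 3 values shown sit. The unmeasured compound 4 `Cc1cc(-c2cccc(Oc3ccc4c(c3)c(=O)ncn4Cc3c(F)cc(F)cc3F)c2C(F)(F)F)cnc1N` differs from compound 1 in one place: 6-amino-5-methylpyridin-3-yl in place of 1H-indol-5-yl on an aromatic carbon. The closest measured step is an at least 3.0-fold higher number from compound 1 to compound 3 (0.47 log units; beyond the scatter), where the plain 6-aminopyridin-3-yl group replaced the same indolyl group, and the parallel step an at least 3.0-fold higher number from compound 2 to compound 3 (0.47 log units; beyond the scatter) matched it. Since compound 4 carries 6-amino-5-methylpyridin-3-yl, a rise of about that size is expected, an at least 2.5-fold higher number from compound 1 to compound 4 (0.39 log units; beyond the scatter). Compound 4 is therefore estimated at 0.25 ug/mL, with a range from 0.07 ug/mL to 0.9 ug/mL.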

Compound 4, solubility: 74 ug/mL
Estimate against measurement, compound 4: 300-fold (2.47 log units) below, and the stated range ends below it.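

In this assay, methyl in place of hydrogen on the aminopyridine alone gives a 250-fold higher number from compound 3 to compound 4 (2.39 log units; beyond the scatter), so one small addition at this position can change the read-out greatly. Against the indoles, the new group gives an at least 740-fold higher number from compound 1 to compound 4 (2.86 log units; beyond the scatter) and an at least 740-fold higher number from compound 2 to compound 4 (2.86 log units; beyond the scatter). Both steps are only lower bounds, since each starts from a limit: the limit of < 0.1 ug/mL in this assay, at which 2 of the 4 values shown sit.

As far as these compounds go, whether an ethyl, a methoxy or a chlorine in that methyl's place would give a similar step stays open. So does whether a methyl on the indoles would do the same.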